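Enlarging the amino group of a potent compound

The source may report more compounds than this note shows. Statements on the series, on what has been measured and on what is new or still open speak of the compounds shown alone.

Compound 1 (`COC/C1=C/C[C@](C)(CCC=C(C)C)/C=C/[C@@H](OC(=O)C=C(C)C)[C@](C)(O)/C=C/C1=O`) and compound 2 (`CC(C)=CCC[C@]1(C)/C=C/[C@@H](OC(=O)C=C(C)C)[C@](C)(O)/C=C/C(=O)/C(CN(C)C)=C\C1`) share one core. In a functional assay on HL-60 cells (Homo sapiens) for antiproliferative activity, read by MTT assay, with a stated time of 48 h (on this read-out higher numbers stand for weaker inhibition and lower numbers for stronger inhibition), compound 1 gives 3070 nM and compound 2 gives 140 nM as the lower of the two numbers, which makes compound 2 the stronger inhibitor. Among the measured compounds shown here, the one measured step (a 22-fold lower number from compound 1 to compound 2 (1.34 log units; beyond the scatter)) is large: dimethylamino in place of methoxy on a saturated chain carbon bound to a double-bonded ring carbon.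

Compound 3 (`CC(C)=CCC[C@]1(C)/C=C/[C@@H](OC(=O)C=C(C)C)[C@](C)(O)/C=C/C(=O)/C(CN(C(C)C)C(C)C)=C\C1`) alters that same group, and diisopropylamino in place of dimethylamino on a saturated chain carbon bound to a double-bonded ring carbon sums up the change, diisopropylamino in place of dimethylamino. For the measured compounds named here, that large step is the only guide, and no measured step compares two amino groups. The expected change in this assay is a 2.1-fold higher number from compound 2 to compound 3 (0.33 log units; beyond the scatter) as a smaller and tentative move toward weaker inhibition. Compound 3 is estimated at 300 nM with 90 nM to 1000 nM as its expected range.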

Compound 3, half-maximal inhibitory concentration: 740 nM
Compound 3: middle estimate off by 2.5-fold (0.39 log units), on the low side; measured number inside the range.
By their numbers in this assay, from the lowest: compound 2; then compound 3; then compound 1.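

In this assay, enlarging the amino group on a saturated chain carbon bound to a double-bonded ring carbon has a measurable cost, and the step is a 5.3-fold higher number from compound 2 to compound 3 (0.72 log units; beyond the scatter) on going from dimethylamino to diisopropylamino. The larger amino group still keeps part of the gain over methoxy, with a 4.1-fold lower number from compound 1 to compound 3 (0.62 log units; beyond the scatter) for diisopropylamino in place of methoxy, so among these three compounds both amino groups give lower numbers than methoxy, and the size of the gain differs with the amino group. Nothing measured here explains why the two amino groups differ.

The compounds shown leave open how a ring amine such as pyrrolidine or morpholine would compare at this place. They also leave open whether diethylamino, which lies between the two amino groups in size, would give a number closer to that of compound 2 or that of compound 3.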